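This account rests on a few compounds, and the source may have more. Where it says the series, first, only, none or still open, it means among the compounds named here.

Compound 1 `CCCn1c(=O)n(C)c(=O)c2c1ncn2CCN(C)C`: in an assay on Cerebral cortex for binding affinity to adenosine receptor A1 (Cavia porcellus), read by radioligand binding (on this read-out lower numbers stand for stronger inhibition and higher numbers for weaker inhibition), compound 1 gives > 200000 nM, which is a limit of the assay and not a number.
Compound 2 `CCCn1c(=O)n(C)c(=O)c2c1ncn2CCCN(C)C`: in this assay compound 2 gives > 200000 nM, again a limit of the assay and not a number.

Compound 2 therefore stands only at the edge of what the assay can report, since (the limit of > 200000 nM in this assay, at which 2 of the 2 values shown sit). Within the data shown here, the one measured step, a step that the two limits leave unreadable from compound 1 to compound 2, runs between two limits and its size cannot be read.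

Compound 3 `CCCn1c(=O)n(C)c(=O)c2c1ncn2CCOCC` has not been measured. It differs from compound 2 by ethoxy in place of (dimethylamino)methyl on a saturated chain carbon, two bonds along the chain from an aromatic nitrogen. Among the measured compounds shown here, no measured step bears on this kind of exchange, and the single step available is itself unreadable, so no direction and no size can be taken from the data. In this assay compound 3 is expected to remain weak, with an estimated step of an at least 1.3-fold lower number from compound 2 to compound 3 (0.12 log units; that floor lies within the scatter). The estimate for compound 3 is 150000 nM, expected to lie between 20000 nM and 1000000 nM, most likely reported again only as a limit.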

Compound 3, inhibition constant: 24300 nM
Compound 3: middle estimate off by 6.2-fold (0.79 log units), on the high side, within the range that was stated.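

Among these compounds, compound 3 is the first to give a real number rather than a limit in this assay, so this position on the chain can respond to the group it carries. The change is visible as an at least 8.2-fold lower number from compound 2 to compound 3 (0.91 log units; beyond the scatter), and the shorter amine chain gives a matching result, an at least 8.2-fold lower number from compound 1 to compound 3 (0.91 log units; beyond the scatter). Both steps are lower bounds rather than true sizes, because each starts from a compound with no numerical value: the limit of > 200000 nM in this assay, at which 2 of the 3 values shown sit.

The compounds shown leave open how large the true difference is and whether it comes from adding the ethoxy oxygen or from removing the dimethylamino nitrogen. A plain butyl chain would help separate those two readings, while a methoxy or propoxy group would show how the result depends on the length of the ether.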